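Moving the Nitro Group from 4-Nitrobenzyl to 2-Nitrobenzyl

This account rests on a few compounds, and the source may have more. Where it says the series, first, only, none or still open, it means among the compounds named here.

Among the compounds with values here, in a physicochemical assay for metabolic stability, at 50 degrees C, tested at 5 uM (a lower number here means that the compound disappears faster, a higher number that the compound lasts longer), compound 3 (`Nc1ncnc2c1ncn2[C@@H]1O[C@@H]2CO[P@@](=O)(OCc3ccc([N+](=O)[O-])cc3)O[C@H]2[C@H]1O`) gives 73 h as its half-life, the second highest of the three numbers so far. Compound 1 (`Nc1ncnc2c1ncn2[C@@H]1O[C@@H]2CO[P@@](=O)(OCc3ccccc3)O[C@H]2[C@H]1O`) sits far lower at 0.5 h on this scale, while compound 2 (`Nc1ncnc2c1ncn2[C@@H]1O[C@@H]2CO[P@](=O)(OCc3ccc([N+](=O)[O-])cc3)O[C@H]2[C@H]1O`) reaches 240 h as the highest number.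

Compound 4 (`Nc1ncnc2c1ncn2[C@@H]1O[C@@H]2CO[P@@](=O)(OCc3ccccc3[N+](=O)[O-])O[C@H]2[C@H]1O`) differs from compound 3 in one place (2-nitrophenyl in place of 4-nitrophenyl on a saturated chain carbon bound to an oxygen), with 2-nitrophenyl in place of 4-nitrophenyl on a saturated chain carbon bound to an oxygen. The nitro group therefore stays in the molecule but is attached differently.

Within the data shown here, two measured steps bear on this change. Putting a nitro group in place of hydrogen gave a large step, a 150-fold higher number from compound 1 to compound 3 (2.16 log units; beyond the scatter) and compound 4 still carries that group. The second step, a 3.3-fold lower number from compound 2 to compound 3 (0.52 log units; beyond the scatter) is modest, and it shows how sensitive this assay can be, given the fact that compounds 2 and 3 differ only in the configuration as drawn as the only difference. As far as these compounds go, neither step moves a nitro group around the ring, so the direction remains open. In this assay no step beyond the scatter is therefore expected, and certainly no fall towards compound 1.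

The estimated change is a 1.2-fold lower number from compound 3 to compound 4 (0.09 log units; within the scatter) and it remains only an expectation. For compound 4 the estimated half-life is 60 h within an expected range of 15 h to 220 h until a measurement arrives.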

Compound 4, half-life: 83 h
Estimate against measurement, compound 4: 1.4-fold (0.14 log units) below; low and high end bracket the measured number.
By their numbers in this assay, from the lowest: compound 1; then compounds 3 and 4 (each within the scatter of the next); then compound 2.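

In this assay, moving the nitro group leaves no readable difference, since 2-nitrophenyl in place of 4-nitrophenyl on a saturated chain carbon bound to an oxygen gives a step within the scatter (a 1.1-fold higher number from compound 3 to compound 4 (0.06 log units; within the scatter)). The large rise seen on adding a nitro group survives the move, as the comparison with the compound lacking that group shows (a 170-fold higher number from compound 1 to compound 4 (2.22 log units; beyond the scatter)). For these two placements, then, having the nitro group counts for far more than where it stands on the ring, although nothing shown explains why the two placements give such similar half-lives.

As far as these compounds go, compound 2 differs from compound 3 only at the phosphorus stereocentre (a 3.3-fold lower number from compound 2 to compound 3 (0.52 log units; beyond the scatter)), so it remains open whether 2-nitrophenyl with the phosphorus drawn as in compound 2 would stay close to compound 4 or rise towards compound 2. From the compounds shown here alone, it is also open whether an amine or a nitrile in place of the nitro group would keep the half-life high or let it fall towards compound 1.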